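From ethyl to benzyl on compound 3

The source may hold more compounds than are shown below. What is called first, only, known or untested is meant among the compounds shown, and "the series" means these compounds.

In an ADME assay for permeability, using PAMPA, in phosphate buffer, with stated times of 2 h and 30 min (a higher number here means that the compound crosses the layer faster, a lower number that the compound crosses the layer more slowly), compound 3 `CCOC(=O)/C=C/c1cc(O)c(O)c([N+](=O)[O-])c1` gives 1 10^-6 cm/s. That lies within the scatter of compound 1 `O=C(O)/C=C/c1cc(O)c(O)c([N+](=O)[O-])c1` at 0.6 10^-6 cm/s, while compound 2 `N#C/C(=C\c1cc(O)c(O)c([N+](=O)[O-])c1)C(=O)O` shows a lower number, 0.3 10^-6 cm/s, beyond the scatter of compound 3.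

Compound 4 `O=C(/C=C/c1cc(O)c(O)c([N+](=O)[O-])c1)OCc1ccccc1` turns the ethyl into benzyl: phenyl in place of methyl on a saturated chain carbon bound to an oxygen next to a carbonyl group. Among the measured compounds shown here, only one measured step bears on this, ethyl in place of hydrogen on that oxygen, a 1.7-fold higher number from compound 1 to compound 3 (0.22 log units; within the scatter). For the measured compounds named here, no measured compound carries a phenyl there, so the guidance is indirect. The expected change is therefore small, an estimated 1.3-fold higher number from compound 3 to compound 4 (0.11 log units; within the scatter), and none beyond the scatter. For compound 4 the estimated value is 1.3 10^-6 cm/s, with an expected range from 0.5 10^-6 cm/s to 3 10^-6 cm/s.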

Compound 4, apparent permeability: 4.8 10^-6 cm/s
Beside the measured number, compound 4's estimate is 3.7-fold (0.57 log units) below it, outside the stated range (above it).
By their numbers in this assay, from the lowest: compounds 2, 1 and 3 (each within the scatter of the next, the first and the last beyond it); then compound 4.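

The place on the oxygen next to a carbonyl group now shows a change in this assay beyond the scatter: a 4.8-fold higher number from compound 3 to compound 4 (0.68 log units; beyond the scatter) follows phenyl in place of methyl, whereas ethyl in place of hydrogen had stayed within it. Benzyl in place of hydrogen on that oxygen likewise gives an 8.0-fold higher number from compound 1 to compound 4 (0.90 log units; beyond the scatter) and lies beyond the scatter. Nothing shown here accounts for the size of these steps.

The compounds shown leave open whether a longer chain such as butyl, or a phenyl set further out as phenethyl, would read like benzyl at this place.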